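This account rests on a few compounds, and the source may have more. Where it says the series, first, only, none or still open, it means among the compounds named here.

Compound 3 `COc1ccc(F)cc1CNCCCNc1ccnc2cc(Cc3ccccc3)ccc12` gives 7990 nM in an ADME assay on HepG2 cells (Homo sapiens) for cytotoxicity, read by luminescence, CellTiter-Glo and ATP content, with a stated time of 72 h (a higher number here means that more compound is needed for the effect, a lower number that less compound is needed), the highest of the three numbers here. Compound 1 `COc1ccc(Oc2ccc3c(NCCCNCc4cc(F)ccc4OC)ccnc3c2)cc1` gives 7000 nM, and the step of a 1.1-fold higher number from compound 1 to compound 3 (0.06 log units; within the scatter) is within the scatter, so these two cannot be told apart. Compound 2 `COc1ccc(F)cc1CNCCCNc1ccnc2cc(Cc3ccc(F)cc3Cl)ccc12` gives 2460 nM; the step of a 3.2-fold higher number from compound 2 to compound 3 (0.51 log units; beyond the scatter) is modest. Compound 4 `COc1ccc(F)cc1CNCCCNc1ccnc2cc(CC3CCCCC3)ccc12` differs from compound 3 by cyclohexyl in place of phenyl on a saturated chain carbon bound to an aromatic carbon. Going by the values given here, the only measured step at this same place is a 3.2-fold higher number from compound 2 to compound 3 (0.51 log units; beyond the scatter), where one aromatic ring replaced another; no measured step trades an aromatic ring for a saturated one, so that step guides only loosely. The expected change is therefore a 1.1-fold lower number from compound 3 to compound 4 (0.06 log units; within the scatter). Compound 4 is estimated at 7000 nM, between 3000 nM and 16000 nM.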

Compound 4, half-maximal effective concentration: 1830 nM
Estimate against measurement, compound 4: 3.8-fold (0.58 log units) above; measured number outside the range, below it.
By their numbers in this assay, from the lowest: compounds 4 and 2 (each within the scatter of the next); then compounds 1 and 3 (each within the scatter of the next).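

Here, in this assay, the ring on the saturated chain carbon need not be aromatic: cyclohexyl in place of phenyl gives a 4.4-fold lower number from compound 3 to compound 4 (0.64 log units; beyond the scatter) and so moves the number modestly. Cyclohexyl also matches the 2-chloro-4-fluorophenyl ring, with a 1.3-fold lower number from compound 2 to compound 4 (0.13 log units; within the scatter), while cyclohexylmethyl in place of 4-methoxyphenoxy gives a 3.8-fold lower number from compound 1 to compound 4 (0.58 log units; beyond the scatter) as a modest step. No evidence at hand explains why the saturated ring gives the lower number. Open, going by these compounds, is whether a smaller cyclopentyl ring would match cyclohexyl, and whether a piperidine ring, which carries an amine, would do the same.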